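This account rests on a few compounds, and the source may have more. Where it says the series, first, only, none or still open, it means among the compounds named here.

Working notes on the series. The shared core of compound 1 `Cn1c(-c2ccc(F)cc2)nc2c(NC3CCCC3)ncnc21` carries a cyclopentylamino group and an aryl ring bearing a fluoro group; in a functional assay on CHO cells for antagonist activity at adenosine receptor A2b (Homo sapiens), read by 33P incorporation, with a stated time of 20 min (on this read-out lower numbers stand for stronger inhibition and higher numbers for weaker inhibition), compound 1 gives > 30000 nM, which is a limit of the assay and not a number. Compound 2 `COc1ccc(-c2nc3c(NC4CCCC4)ncnc3n2C)cc1` has methoxy in place of fluoro on that aromatic carbon; in this assay compound 2 gives > 30000 nM, again a limit. Compound 3 `Cn1c(-c2ccc(C(=O)O)cc2)nc2c(NC3CCCC3)ncnc21` has carboxy in that place; in this assay compound 3 gives > 30000 nM, also a limit. Compound 3 therefore stands at the limit of > 30000 nM in this assay, at which 3 of the 3 values shown sit, and nothing separates it from the other two. The steps a step that the two limits leave unreadable from compound 1 to compound 2, a step that the two limits leave unreadable from compound 1 to compound 3 and a step that the two limits leave unreadable from compound 2 to compound 3 all remain unreadable.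

Compound 4 `Cn1c(-c2ccc(O)cc2)nc2c(NC3CCCC3)ncnc21` differs from compound 3 as follows: hydroxy in place of carboxy on an aromatic carbon. For the measured compounds named here, the steps that bear on this change are the unreadable ones from compound 1 and compound 2 to compound 3, so no size can be read from them; three substituents at this carbon have all stayed at the limit. For compound 4 the expectation in this assay is accordingly another value at or near the limit, an estimated step of a number no higher from compound 3 to compound 4 (the limit leaves the size open). The estimate for compound 4 is 30000 nM, with a range from 10000 nM to 100000 nM.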

Compound 4, inhibition constant: 17800 nM
Compound 4: the middle estimate sits 1.7-fold (0.23 log units) above what was measured; low and high end bracket the measured number.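

Hydroxy is the first group at this aromatic carbon to give a number rather than a limit in this assay: the change from carboxy gives an at least 1.6-fold lower number from compound 3 to compound 4 (0.22 log units; that floor lies within the scatter). The other two comparisons read the same way, with hydrogen taking the place of methyl on the oxygen in an at least 1.6-fold lower number from compound 2 to compound 4 (0.22 log units; that floor lies within the scatter) and hydroxy taking the place of fluoro in an at least 1.6-fold lower number from compound 1 to compound 4 (0.22 log units; that floor lies within the scatter). Each of these is only a floor that lies within the scatter, so no real gain is established, and what sets hydroxy apart from fluoro, methoxy and carboxy so far is only that those three stay at the limit: the limit of > 30000 nM in this assay, at which 3 of the 4 values shown sit.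

Going by these compounds, the steps among compound 1, compound 2 and compound 3 cannot be read, and the true size of the three new steps stays open. Also open, on these data alone, is whether an amine or a hydroxymethyl group at this aromatic carbon, or a longer chain in place of the cyclopentylamino group, would give a number clearly lower than that of compound 4.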